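A Methyl Next to the Ring Nitrogen on a Naphthyl Analogue

This account rests on a few compounds, and the source may have more. Where it says the series, first, only, none or still open, it means among the compounds named here.

Of the compounds shown here, three have been measured in a functional assay on U-251 cells (Homo sapiens) for antiproliferative activity; a higher number here means a weaker inhibitor of growth, a lower number a stronger inhibitor of growth. Compound 1 `Cc1ccc2c(O)cc(-c3cccc(Cl)c3)nc2n1` gives 64.6 nM. Compound 3 `Cc1cc(C)c2c(O)cc(-c3cccc(Cl)c3)nc2n1` gives 295 nM, and compound 2 `Oc1cc(-c2ccc3ccccc3c2)nc2ncccc12` gives 4370 nM, the highest of the three numbers. The difference between compound 1 and compound 2 is not broken down here.

Compound 1 and compound 3 differ in one place, (methyl in place of hydrogen on an aromatic carbon), and the step is a 4.6-fold higher number from compound 1 to compound 3 (0.66 log units; beyond the scatter). Compound 4 `Cc1ccc2c(O)cc(-c3ccc4ccccc4c3)nc2n1` has not yet been measured in this assay. It differs from compound 2 by methyl in place of hydrogen on an aromatic carbon. For the measured compounds named here, this is the same kind of change as the one from compound 1 to compound 3, not the same: in compound 3 the methyl sits ortho to a fused ring, meta to a fused ring, meta to a methyl group and opposite the ring nitrogen, whereas in compound 4 it sits next to the ring nitrogen, meta to a fused ring and para to a fused ring. Compound 1, which carries a methyl at this same place, gives 64.6 nM, the lowest of the measured numbers, so the methyl at this place does not by itself appear to hurt. Going by the values given here, the only measured step for this kind of change, a 4.6-fold higher number from compound 1 to compound 3 (0.66 log units; beyond the scatter), sits at a different place and is taken as a weak guide.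

Compound 4 is expected to sit close to compound 2, with a step estimated as a 1.5-fold lower number from compound 2 to compound 4 (0.16 log units; within the scatter). The estimate for compound 4 is 3000 nM, with a range from 800 nM to 12000 nM.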

Compound 4, concentration for 50% growth inhibition: 4570 nM
Compound 4: the middle estimate sits 1.5-fold (0.18 log units) below what was measured, and the stated range covers the measured number.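

In this assay, replacing hydrogen with methyl next to the ring nitrogen on the core of compound 2 gives a step that cannot be told from the scatter, with a 1.0-fold higher number from compound 2 to compound 4 (0.02 log units; within the scatter). The same kind of replacement on the core of compound 1 gives a clearly larger step, so the size of the step seen on one core did not carry over to the other: the same change on two cores in this assay, a 4.6-fold higher number (0.66 log units; beyond the scatter) from compound 1 to compound 3 and a 1.0-fold higher number (0.02 log units; within the scatter) from compound 2 to compound 4, 4.4-fold (0.64 log units) apart, beyond the scatter of two such steps

For the compounds shown here, what this does not show is that the core alone sets the size of the step: the methyl enters at a different place in the two pairs, compound 3 carries it alongside a methyl already present in compound 1, and each core offers only a single pair.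

The compounds shown leave open how the core of compound 2 would respond to a methyl at the place it occupies in the step to compound 3, and how the core of compound 1 would respond to that methyl with no other methyl present. They also leave open whether an ethyl group, a methoxy group or an amine next to the ring nitrogen would stand any differently from methyl on either core.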